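The compounds below may be only part of what the source reports. "The series", "measured", "known", "first", "only" and "open" are said of these compounds alone.

Compound 1 `NC(=O)c1c(NC(=O)c2ccc(C(F)(F)F)cc2)sc2c1CCN(C(=S)Nc1ccccc1Cl)C2` gives 36100 nM in a functional assay on HL-60 cells (Homo sapiens) for antiproliferative activity, with a stated time of 24 h; a lower number here means a stronger inhibitor, a higher number a weaker inhibitor. Compound 2 `Cc1ccc(C(=O)Nc2sc3c(c2C(N)=O)CCN(C(=S)Nc2ccccc2Cl)C3)cc1` carries one change at the benzamide end, (methyl in place of trifluoromethyl on an aromatic carbon), and in this assay compound 2 gives 8430 nM, so that a 4.3-fold lower number from compound 1 to compound 2 (0.63 log units; beyond the scatter). Compound 3 `NC(=O)c1c(NC(=O)c2ccc(C(F)(F)F)cc2)sc2c1CCN(C(=S)Nc1cc(C(F)(F)F)cc(C(F)(F)F)c1)C2` has a different thiourea end; the difference between its core and that of compound 1 is not broken down here. In this assay compound 3 gives 16300 nM. Compound 4 `Cc1ccc(C(=O)Nc2sc3c(c2C(N)=O)CCN(C(=S)Nc2cc(C(F)(F)F)cc(C(F)(F)F)c2)C3)cc1` is not yet measured; it differs from compound 3 by the same change, (methyl in place of trifluoromethyl on an aromatic carbon). For the measured compounds named here, the step from compound 3 to compound 4 is expected to be of similar size, a 4.1-fold lower number from compound 3 to compound 4 (0.61 log units; beyond the scatter), because the only earlier example of this change gave a 4.3-fold lower number from compound 1 to compound 2 (0.63 log units; beyond the scatter). Compound 4 is therefore estimated at 4000 nM, expected between 1500 nM and 10000 nM.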

Compound 4, half-maximal inhibitory concentration: 11800 nM
Beside the measured number, compound 4's estimate is 3.0-fold (0.47 log units) below it; measured number above the stated range.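

In this assay, methyl in place of trifluoromethyl gives a 1.4-fold lower number from compound 3 to compound 4 (0.14 log units; within the scatter), so on this core the change has no readable effect. For the compounds shown here, the change therefore does not carry over at a constant size between the two cores: the same change on two cores in this assay, a 4.3-fold lower number (0.63 log units; beyond the scatter) from compound 1 to compound 2 and a 1.4-fold lower number (0.14 log units; within the scatter) from compound 3 to compound 4, 3.1-fold (0.49 log units) apart, beyond the scatter of two such steps With only two pairs, this does not show why the cores differ, or what size the step would have on a third core.

The compounds shown leave open how other groups in the same place on the ring, such as a methoxy group, an amine or a carboxylic acid, would compare with methyl and trifluoromethyl. Going by these compounds, it is also open whether a thiourea end carrying a longer chain instead of an aromatic ring would give a step like either of these two.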